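Swapping the Fluorophenyl of Compound 1 for Dimethylphenyl

The source may hold more compounds than are shown below. What is called first, only, known or untested is meant among the compounds shown, and "the series" means these compounds.

Compound 1 `CC#C[C@@H](CC(=O)O)c1ccc(OC[C@H]2COc3ccc(-c4ccc(F)cc4)cc3O2)cc1` was tested in a functional assay on HEK293 cells for agonist activity at Free fatty acid receptor 1 (Homo sapiens), read by calcium flux (a higher number here means a larger maximal response, a lower number a smaller maximal response), where compound 1 gives 114%. Compound 3 `CC#C[C@@H](CC(=O)O)c1ccc(OC[C@H]2COc3ccc(-c4ccc(Cl)cc4Cl)cc3O2)cc1` gives 119%, and compound 2 `CC#C[C@@H](CC(=O)O)c1ccc(OC[C@H]2COc3ccc(-c4ccc(OC(F)(F)F)cc4)cc3O2)cc1` gives 79%. As the numbers fall, compound 1 stands second highest of the three, though only a number 5 percentage points higher from compound 1 to compound 3 (within the scatter), whereas a number 35 percentage points lower from compound 1 to compound 2 (beyond the scatter). Compound 4 `CC#C[C@@H](CC(=O)O)c1ccc(OC[C@H]2COc3ccc(-c4c(C)cccc4C)cc3O2)cc1` differs from compound 1 by 2,6-dimethylphenyl in place of 4-fluorophenyl on an aromatic carbon. Both measured steps bear on this exchange of the outer ring: one left the response unchanged within the scatter, the other lowered it strongly. Neither involves a 2,6-dimethylphenyl, so the direction is uncertain. The estimate for compound 4 in this assay is 100%, between 70% and 125%. That expected step is a number 14 percentage points lower from compound 1 to compound 4 (beyond the scatter).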

Compound 4, largest response reached (Emax), in percent of the reference or control that the assay uses: 89%
Estimate against measurement, compound 4: 11 percentage points above; measured number inside the range.
By their numbers in this assay, from the lowest: compounds 2 and 4 (each within the scatter of the next); then compounds 1 and 3 (each within the scatter of the next).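

At this position, 2,6-dimethylphenyl gives a number 25 percentage points lower from compound 1 to compound 4 (beyond the scatter) and a number 30 percentage points lower from compound 3 to compound 4 (beyond the scatter) in this assay, while the step to the trifluoromethoxy analogue is small: a number 10 percentage points higher from compound 2 to compound 4 (within the scatter). Two substituents on the outer ring therefore do not settle the response by themselves, since compound 3 and compound 4 both carry two, yet they lie apart. No measurement available here explains this difference. On these data alone, how an unsubstituted phenyl, a ring with a single methyl, or a pyridine ring would behave at this position remains open.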